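The source may hold more compounds than are shown below. What is called first, only, known or untested is meant among the compounds shown, and "the series" means these compounds.

Measured so far, in a functional assay on HeLa cells (Homo sapiens) for cytotoxicity, read by MTT assay, with a stated time of 72 h; a higher number here means a weaker inhibitor, a lower number a stronger inhibitor:
compound 1 `CC(=O)OCC(=O)N(/N=N/c1ccc([N+](=O)[O-])cc1Br)c1ccc([N+](=O)[O-])cc1Br` gives 490 nM;
compound 2 `O=C(c1ccccc1)N(/N=N/c1ccc([N+](=O)[O-])cc1Cl)c1ccc([N+](=O)[O-])cc1Cl` gives 590 nM.

Compound 2 thus carries the highest of the two numbers, with compound 1 its nearest neighbour, and the gap between them lies within the scatter. Compound 3 `COC(=O)N(/N=N/c1ccc([N+](=O)[O-])cc1Cl)c1ccc([N+](=O)[O-])cc1Cl` is not yet measured in this assay. It differs from compound 2 in one place: methoxy in place of phenyl on a carbonyl carbon. Among the compounds with values here, no comparable step between measured compounds is available, so a step beyond the scatter is not expected in either direction. Compound 3 is therefore estimated to give 600 nM, within 250 nM to 1500 nM, meaning a step of a 1.0-fold higher number from compound 2 to compound 3 (0.01 log units; within the scatter).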

Compound 3, half-maximal inhibitory concentration: 980 nM
For compound 3 the middle estimate is 1.6-fold (0.21 log units) below the measured one, within the range that was stated.
By their numbers in this assay, from the lowest: compounds 1, 2 and 3 (each within the scatter of the next).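

In this assay, within the data shown here, the step of a 1.7-fold higher number from compound 2 to compound 3 (0.22 log units; within the scatter) is the first reading at this position, and it lies within the scatter. Benzoyl to methoxycarbonyl thus removes the six-membered aromatic ring and brings in a hydrogen-bond acceptor without a step beyond the scatter in this assay. No supporting measurement is available that bears on this result.

The compounds shown leave open whether an amine or a longer alkyl chain on this carbonyl carbon would also stay within the scatter. Compound 1 differs from compound 3 in more than one place, so it does not settle this.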